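The source may hold more compounds than are shown below. What is called first, only, known or untested is meant among the compounds shown, and "the series" means these compounds.

This account follows a small set of compounds that share a core, all tested in a functional assay on HepG2 cells (Homo sapiens) for inhibition, read by MTT assay, with a stated time of 72 h (on this read-out lower numbers stand for stronger inhibition and higher numbers for weaker inhibition), for how well they hold back the cells. Among the compounds with values here, compound 1 `CNC(=O)CCCCCCCn1nc(-c2cnc3[nH]ccc3c2)c2c(N)ncnc21` gives 5630 nM as the only true number so far. Compound 2 `Nc1nc2cc(-c3nn(CCCC(=O)NO)c4ncnc(N)c34)ccc2o1` gives > 50000 nM and that is a limit of the assay, not a number. Compound 3 `Nc1nc2cc(-c3nn(CC(=O)NO)c4ncnc(N)c34)ccc2o1` gives > 150000 nM and this too is only a limit, so compound 3 has no exact place on the scale.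

Compound 4 `CNC(=O)CCCCCCCn1nc(-c2ccc3oc(N)nc3c2)c2c(N)ncnc21` has not yet been measured. Its difference from compound 3 is 6-(methylcarbamoyl)hexyl in place of hydroxycarbamoyl on a saturated chain carbon bound to an aromatic nitrogen and this puts a much longer chain on the core. Within the data shown here, the one measured step on this side chain is a step that the two limits leave unreadable from compound 2 to compound 3 and so it offers no size to carry over. Compound 1 carries the same chain and gives 5630 nM as the nearest real number, although the rest of its structure is not identical to that of compound 4.

A move to a lower number, meaning stronger inhibition, is therefore expected, and the estimated step is an at least 7.5-fold lower number from compound 3 to compound 4 (0.87 log units; beyond the scatter) with its size loosely known. In this assay the estimate for compound 4 is 20000 nM with an expected range from 4000 nM to 100000 nM and a real chance that the outcome is only a limit.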

Compound 4, half-maximal inhibitory concentration: 3640 nM
Compound 4: middle estimate off by 5.5-fold (0.74 log units), on the high side, outside the stated range (below it).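

In this assay, 6-(methylcarbamoyl)hexyl in place of the short hydroxycarbamoyl side chains, on a saturated chain carbon bound to an aromatic nitrogen, brings an at least 41-fold lower number from compound 3 to compound 4 (1.61 log units; beyond the scatter) and an at least 13-fold lower number from compound 2 to compound 4 (1.13 log units; beyond the scatter), so this position clearly tolerates the long chain and gains from it. Both of these steps start from a limit of the assay and not from a number, so each gives only a minimum size. With the long chain kept in place, exchanging the aromatic group on the core gives a 1.5-fold lower number from compound 1 to compound 4 (0.19 log units; within the scatter), so the two aromatic groups of compound 1 and compound 4 cannot be told apart here, and the side chain is the change that counts in this series.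

The step between compound 2 and compound 3 cannot be read, and the change to compound 4 alters chain length and end group together, so a 6-(hydroxycarbamoyl)hexyl chain or a short chain ending in methylcarbamoyl would be needed to separate the two. On these data alone, whether a carboxylic acid or an amine at the end of the long chain would serve as well also stays open.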